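Switching the arylidene aryl group in a chalcone series

The compounds below may be only part of what the source reports. "The series", "measured", "known", "first", "only" and "open" are said of these compounds alone.

Of the compounds shown here, three have been measured so far. Compound 1 `COc1cc(/C=C/C(=O)c2cccc(-n3cc(-c4ccc(Cl)cc4)[nH]c3=O)c2)ccc1O` gives 2000 nM in a functional assay on OVCAR-5 cells (Homo sapiens) for inhibition; on this read-out lower numbers stand for stronger inhibition of growth and higher numbers for weaker inhibition of growth. Compound 2 `COc1cc(/C=C/C(=O)c2cccc(-n3cc(-c4ccccc4)[nH]c3=O)c2)ccc1O` gives 2040 nM in this assay, and compound 3 `COc1ccc(-c2cn(-c3cccc(C(=O)/C=C/c4cc(OC)c(OC)c(OC)c4)c3)c(=O)[nH]2)cc1` gives 2640 nM. Compound 3 carries the highest of the three numbers, but its gaps to compound 2 and to compound 1 both lie within the scatter, so no order among the three can be read from these values.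

Among the compounds with values here, the only step between measured compounds that differ in one place is a 1.0-fold higher number from compound 1 to compound 2 (0.01 log units; within the scatter), a change on the aryl group attached to the shared core that leaves the number unchanged within the scatter.

Compound 4 `COc1ccc(-c2cn(-c3cccc(C(=O)/C=C/c4ccc(O)c(OC)c4)c3)c(=O)[nH]2)cc1` is to be measured in this assay. It differs from compound 3 as follows: 4-hydroxy-3-methoxyphenyl in place of 3,4,5-trimethoxyphenyl on a double-bonded chain carbon bound to a double-bonded chain carbon. Compounds 1 and 2 already carry the 4-hydroxy-3-methoxyphenyl group that enters here, and their numbers sit close to that of compound 3, though they differ from compound 3 and compound 4 elsewhere as well, so they bear on this step only indirectly. Within the data shown here, no measured step addresses this exchange directly. The expectation is therefore a step of a 1.3-fold lower number from compound 3 to compound 4 (0.10 log units; within the scatter), no change beyond the scatter. For compound 4 the estimate is 2100 nM, with a range from 900 nM to 5000 nM.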

Compound 4, concentration for 50% growth inhibition: 3380 nM
Beside the measured number, compound 4's estimate is 1.6-fold (0.21 log units) below it, and the stated range covers the measured number.
By their numbers in this assay, from the lowest: compounds 1, 2, 3 and 4 (each within the scatter of the next).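

In this assay, the exchange of 3,4,5-trimethoxyphenyl for 4-hydroxy-3-methoxyphenyl on a double-bonded chain carbon bound to a double-bonded chain carbon now has a direct reading, and it stays within the scatter (a 1.3-fold higher number from compound 3 to compound 4 (0.11 log units; within the scatter)), although the entering group brings 1 hydrogen-bond donor where the leaving group has 0. With the 4-hydroxy-3-methoxyphenyl group held fixed, the aryl group on the shared core also gains two further readings, methoxy in place of hydrogen (a 1.7-fold higher number from compound 2 to compound 4 (0.22 log units; within the scatter)) and methoxy in place of chloro (a 1.7-fold higher number from compound 1 to compound 4 (0.23 log units; within the scatter)), both within the scatter, so hydrogen, chloro and methoxy at that place cannot be told apart on these numbers. Nothing available on these compounds offers an account of the readings beyond the numbers themselves.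

Neither place has yet given a step beyond the scatter, so how sensitive either one is remains undetermined. Still open, on these data alone, is whether a group of another kind, such as a carboxylic acid or an amine in place of the 4-hydroxy-3-methoxyphenyl group, or a longer alkoxy chain in place of methoxy on the other aryl group, would shift the number beyond the scatter.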